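Varying the ester substituent in a small adenosine A2b series

A few compounds are considered here, and "the series" means these few. Any claim that something is new, unique, unknown or untested is made for them only; others in the source may bear on it.

Compound 1 `CC1=C(C(=O)OCc2ccccc2)C(c2ccco2)NC(=O)N1` gives 887 nM in an assay on membranes from HEK293 cells for displacement of a labelled ligand from adenosine receptor A2b (Homo sapiens), read by scintillation counting, with a stated time of 30 min; a higher number here means a weaker inhibitor, a lower number a stronger inhibitor. Compound 2 `CCC(C)OC(=O)C1=C(C)NC(=O)NC1c1ccco1` gives 84.3 nM. Compound 3 `CC1=C(C(=O)OC2CCCC2)C(c2ccco2)NC(=O)N1` gives 577 nM.

Compound 3 stands second highest of the three: compound 1 is its nearest neighbour (a 1.5-fold lower number from compound 1 to compound 3 (0.19 log units; within the scatter)), compound 2 its furthest (a 6.8-fold higher number from compound 2 to compound 3 (0.84 log units; beyond the scatter)). Compound 4 `CC1=C(C(=O)OCC2CCC2)C(c2ccco2)NC(=O)N1` differs from compound 3 by cyclobutylmethyl in place of cyclopentyl on an oxygen next to a carbonyl group. Among the compounds with values here, the steps that bear on this all change the same oxygen: an 11-fold lower number from compound 1 to compound 2 (1.02 log units; beyond the scatter), a 6.8-fold higher number from compound 2 to compound 3 (0.84 log units; beyond the scatter) and a 1.5-fold lower number from compound 1 to compound 3 (0.19 log units; within the scatter). Only the sec-butyl of compound 2 gave a clearly lower number, so the expectation for compound 4 is a small step, a 1.6-fold lower number from compound 3 to compound 4 (0.22 log units; within the scatter), downward but hardly beyond the scatter. Compound 4 is therefore estimated at 350 nM, with a range from 120 nM to 1000 nM.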

Compound 4, inhibition constant: 561 nM
Beside the measured number, compound 4's estimate is 1.6-fold (0.20 log units) below it; the measured number falls inside the stated range.
By their numbers in this assay, from the lowest: compound 2; then compounds 4, 3 and 1 (each within the scatter of the next).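

Swapping cyclopentyl for cyclobutylmethyl on this oxygen, with the same atoms joined differently, leaves the number effectively unchanged (a 1.0-fold lower number from compound 3 to compound 4 (0.01 log units; within the scatter)). The gap to the sec-butyl ester remains (a 6.7-fold higher number from compound 2 to compound 4 (0.82 log units; beyond the scatter)), while cyclobutyl in place of phenyl on the saturated chain carbon bound to this oxygen stays within the scatter (a 1.6-fold lower number from compound 1 to compound 4 (0.20 log units; within the scatter)). Among these four esters, therefore, only compound 2 stands apart. As far as these compounds go, whether an isopropyl or a longer chain such as n-butyl would track compound 2 or the other three remains open. No available evidence accounts for the separate standing of compound 2.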